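Swapping the amide for a carboxyphenylsulfonyl on the piperidine

This account rests on a few compounds, and the source may have more. Where it says the series, first, only, none or still open, it means among the compounds named here.

Compound 1 `O=C(c1ccccc1)N1CCC(NS(=O)(=O)c2cc(S(=O)(=O)c3ccccc3)ccc2C(F)(F)F)CC1` gives 70 nM in an assay on isolated protein for displacement of a labelled ligand from secreted frizzled-related protein 1 (Homo sapiens), read by fluorescence polarization, with a stated time of 30 min; on this read-out higher numbers stand for weaker inhibition and lower numbers for stronger inhibition. Compound 2 `O=C(c1ccc(C(F)(F)F)cc1)N1CCC(NS(=O)(=O)c2cc(S(=O)(=O)c3ccccc3)ccc2C(F)(F)F)CC1` gives 400 nM. Compound 3 `O=C(c1ccc(Cl)nc1)N1CCC(NS(=O)(=O)c2cc(S(=O)(=O)c3ccccc3)ccc2C(F)(F)F)CC1` gives 110 nM.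

Compound 3 stands second highest of the three numbers; its nearest neighbour is compound 1, and a 1.6-fold higher number from compound 1 to compound 3 (0.20 log units; within the scatter), while a 3.6-fold lower number from compound 2 to compound 3 (0.56 log units; beyond the scatter). Compound 4 `O=C(O)c1ccc(S(=O)(=O)N2CCC(NS(=O)(=O)c3cc(S(=O)(=O)c4ccccc4)ccc3C(F)(F)F)CC2)cc1` carries (4-carboxyphenyl)sulfonyl in place of (6-chloropyridin-3-yl)carbonyl on an amine nitrogen in a ring. The measured steps all alter the group on this same ring nitrogen: a 5.7-fold higher number from compound 1 to compound 2 (0.76 log units; beyond the scatter) and a 3.6-fold lower number from compound 2 to compound 3 (0.56 log units; beyond the scatter) were both modest. None of them exchanges a carbonyl for a sulfonyl or introduces a carboxylic acid, so the direction is uncertain. A modest shift is therefore expected, a 1.8-fold higher number from compound 3 to compound 4 (0.26 log units; within the scatter). Compound 4 is estimated at 200 nM, with a range from 50 nM to 900 nM.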

Compound 4, half-maximal inhibitory concentration: 20 nM
Compound 4: the middle estimate sits 10-fold (1.00 log units) above what was measured, and the stated range ends above it.
By their numbers in this assay, from the lowest: compound 4; then compounds 1 and 3 (each within the scatter of the next); then compound 2.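

In this assay, placing (4-carboxyphenyl)sulfonyl on the ring nitrogen gives a 5.5-fold lower number from compound 3 to compound 4 (0.74 log units; beyond the scatter), together with a 3.5-fold lower number from compound 1 to compound 4 (0.54 log units; beyond the scatter) and a 20-fold lower number from compound 2 to compound 4 (1.30 log units; beyond the scatter). Compound 4 therefore has the lowest number of the four, whereas no earlier change on this nitrogen gave a number below that of compound 1. Nothing available explains this drop.

On these data alone, the sulfonyl and the carboxylic acid enter together, so their separate contributions remain open. A plain phenylsulfonyl group and a 4-carboxybenzoyl group on this nitrogen would tell them apart.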